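Swapping the Benzimidazole Arm for a Hydroxyethyl Phenyl

The source may hold more compounds than are shown below. What is called first, only, known or untested is meant among the compounds shown, and "the series" means these compounds.

Of the compounds shown here, three sharing one core have been measured in a physicochemical assay for solubility, read by HPLC, in simulated intestinal fluid, with a stated time of 16 h, tested at 125 ug/mL; on this read-out lower numbers stand for lower solubility and higher numbers for higher solubility. Compound 1 `CNC(=O)c1cc(C(=O)NC2CCC2)cn(Cc2ccncc2)c1=O` gives 121 ug/mL. Compound 2 `CNC(=O)c1cc(C(=O)NC2CC2)c(C)n(Cc2ccccc2)c1=O` gives 577 ug/mL. Compound 3 `CNC(=O)c1cc(C(=O)NC2CC2)cn(Cc2ccc3nc[nH]c3c2)c1=O` gives 225 ug/mL. On these numbers compound 3 sits between the other two: its gap to compound 1 lies within the usual scatter, so the two cannot be told apart in this assay, while its gap to compound 2 lies beyond the scatter, and compound 2 clearly shows the greater solubility of the three.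

Compound 4 `CNC(=O)c1cc(C(=O)NC2CC2)cn(Cc2cccc([C@@H](C)O)c2)c1=O` has not yet been measured. It differs from compound 3 in one place only: 3-(1-hydroxyethyl)phenyl in place of 1H-benzimidazol-6-yl on a saturated chain carbon bound to an aromatic nitrogen. A fused two-ring group carrying one donor and one acceptor is exchanged for a single benzene ring bearing a hydroxyethyl group, again with one donor and one acceptor, and the count of heavy atoms stays the same.

Among the measured compounds shown here, no measured pair here shows the effect of such a change, so the expectation rests on compound 3 alone. The step from compound 3 to compound 4 is expected to be a 1.0-fold higher number from compound 3 to compound 4 (0.01 log units; within the scatter), that is, no clear move beyond the scatter in either direction. Compound 4 is therefore estimated at 230 ug/mL, with a plausible range from 90 ug/mL to 600 ug/mL.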

Compound 4, solubility: 495 ug/mL
Beside the measured number, compound 4's estimate is 2.2-fold (0.33 log units) below it, and the stated range covers the measured number.
By their numbers in this assay, from the lowest: compounds 1 and 3 (each within the scatter of the next); then compounds 4 and 2 (each within the scatter of the next).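

Among the compounds shown here, the exchange of 1H-benzimidazol-6-yl for 3-(1-hydroxyethyl)phenyl gives a 2.2-fold higher number from compound 3 to compound 4 (0.34 log units; beyond the scatter) in this assay, the first comparison in this set with only one place changed. It shows that, with the rest of the molecule held fixed, the group on a saturated chain carbon bound to an aromatic nitrogen can shift this read-out beyond the usual scatter, even though the heavy-atom, donor and acceptor counts of the two groups match, so those counts alone do not settle the number here. The change still bundles several differences, from a fused pair of rings to a single benzene ring, from nitrogen to oxygen, and the arrival of a defined stereocentre, and no measurement shown explains the step.

The compounds shown leave open which of those differences carries the step, since no pair separates them and the opposite stereocentre of the 1-hydroxyethyl group is not among them. They also leave open how this position would respond to a different group on the benzene ring, such as an amine, a carboxylic acid or a longer hydroxyalkyl chain.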